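Trimming the carbamate of compound 1 to a plain acetamide

The source may report more compounds than this note shows. Statements on the series, on what has been measured and on what is new or still open speak of the compounds shown alone.

Compound 1 `CCCCc1ccc(CNC(=O)OC(C)(C)C)c(=O)n1Cc1ccc(-c2ccccc2-c2nn[nH]n2)cc1` is a pyridinone-based antagonist. In a functional assay (aorta) for antagonist activity, with Oryctolagus cuniculus as the target (a lower number here means a stronger inhibitor, a higher number a weaker inhibitor), compound 1 gives 10 nM. Among the three measured compounds it stands second highest: compound 3 `CCCCc1ccc(CNC(=O)N(C)C)c(=O)n1Cc1ccc(-c2ccccc2-c2nn[nH]n2)cc1` gives 2 nM, compound 2 `CCCCc1ccc(CNC(=O)NC2CCCCC2)c(=O)n1Cc1ccc(-c2ccccc2-c2nn[nH]n2)cc1` gives 90 nM.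

Compound 4 `CCCCc1ccc(CNC(C)=O)c(=O)n1Cc1ccc(-c2ccccc2-c2nn[nH]n2)cc1` differs from compound 1 in one place: methyl in place of tert-butoxy on a carbonyl carbon. The group on the carbonyl carbon thus becomes far smaller, so the (tert-butoxycarbonyl)amino ends up as acetamido.

Two measured steps change the same carbonyl substituent and so bear on this one. a 9.0-fold higher number from compound 1 to compound 2 (0.95 log units; beyond the scatter) shows that a bulkier group gave a weaker inhibitor. a 5.0-fold lower number from compound 1 to compound 3 (0.70 log units; beyond the scatter) shows that a more compact group gave a stronger one, and a 45-fold lower number from compound 2 to compound 3 (1.65 log units; beyond the scatter) points the same way. Within this small set, then, the less bulky groups on that carbonyl carbon went with the lower numbers. Within the data shown here, a methyl is smaller still, so a modest move towards a lower number, somewhat like that seen for compound 3, is expected for compound 4, though with real uncertainty because only the step of a 5.0-fold lower number from compound 1 to compound 3 (0.70 log units; beyond the scatter) is a direct precedent.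

Compound 4 is therefore estimated at 5 nM, with a plausible range from 1.5 nM to 20 nM, meaning an expected 2.0-fold lower number from compound 1 to compound 4 (0.30 log units; within the scatter).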

Compound 4, half-maximal inhibitory concentration: 3 nM
For compound 4 the middle estimate is 1.7-fold (0.22 log units) above the measured one; low and high end bracket the measured number.
By their numbers in this assay, from the lowest: compounds 3 and 4 (each within the scatter of the next); then compound 1; then compound 2.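

In this assay, the acetamide shows that a low number at this carbonyl carbon does not need a nitrogen-linked group: methyl in place of tert-butoxy gives a 3.3-fold lower number from compound 1 to compound 4 (0.52 log units; beyond the scatter) and methyl in place of cyclohexylamino gives a 30-fold lower number from compound 2 to compound 4 (1.48 log units; beyond the scatter) in the same direction. Methyl in place of dimethylamino gives a 1.5-fold higher number from compound 3 to compound 4 (0.18 log units; within the scatter) so these two groups cannot be told apart in this test. The trend of smaller groups going with lower numbers therefore holds among these four compounds only as far as dimethylamino, and compound 4 goes against any further lowering on the way down to methyl. The data shown give no reason for any of these differences.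

The compounds shown leave open whether an ethyl, a methoxy or a cyclopropyl on this carbonyl carbon would stay level with compound 3 and compound 4. They also leave open where, on the way from methyl up to cyclohexylamino, the number begins to climb, and whether a longer chain such as butyl would follow the same course.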